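The source may hold more compounds than are shown below. What is called first, only, known or untested is meant among the compounds shown, and "the series" means these compounds.

Working notes on the series. The compounds share one core carrying a benzyl group that bears a chloromethyl substituent; they differ in where that substituent sits on the benzyl ring and in the number of chloro groups on the core. Compound 1 `ClCc1cccc(Cn2cnc3c(Cl)nc(Cl)nc32)c1` gives > 100000 nM in a functional assay on CCRF-CEM cells (Homo sapiens) for cytotoxicity, read by sulforhodamine B assay, with a stated time of 48 h (on this read-out higher numbers stand for weaker inhibition of growth and lower numbers for stronger inhibition of growth), which is a limit of the assay and not a number, namely (the limit of > 100000 nM in this assay, at which 1 of the 3 values shown sits). Compound 2 `ClCc1ccccc1Cn1cnc2ncnc(Cl)c21` gives 3540 nM in this assay, the lowest of the two numbers shown. Compound 3 `ClCc1ccc(Cn2cnc3c(Cl)nc(Cl)nc32)cc1` gives 4570 nM in this assay; this value and that of compound 2 lie within the scatter of each other, so no order between them is claimed. Compound 4 `ClCc1ccccc1Cn1cnc2nc(Cl)nc(Cl)c21` has not yet been measured in this assay. It differs from compound 2 in one place: chloro in place of hydrogen on an aromatic carbon. Going by the values given here, no measured pair isolates this change, so its size is unknown; since compound 3, which carries two chloro groups, gives 4570 nM, a step of no more than the scatter in this assay is expected, in either direction. Compound 4 is therefore estimated at 3000 nM in this assay, with a range from 800 nM to 12000 nM. The expected step of a 1.2-fold lower number from compound 2 to compound 4 (0.07 log units; within the scatter) is small.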

Compound 4, concentration for total growth inhibition: 300 nM
The estimate for compound 4 lay 10-fold (1.00 log units) above the measured number; the measured number lies below the stated range.
By their numbers in this assay, from the lowest: compound 4; then compounds 2 and 3 (each within the scatter of the next). At a limit, above all of these: compound 1.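

Chloro in place of hydrogen on the aromatic carbon between two ring nitrogen atoms is the first change in the series that can be read in one place, and in this assay it gives a 12-fold lower number from compound 2 to compound 4 (1.07 log units; beyond the scatter). This position is therefore not neutral in this assay: with chloro there, growth inhibition is clearly stronger than with hydrogen. Compounds 1 and 3 also carry two chloro groups, but each differs from compound 2 in more than one place, so neither could isolate this step.

From the compounds shown here alone, it remains open whether another group at this position, such as an amine or a methoxy group, would give a step of similar size, and whether the step holds with chloromethyl elsewhere on the benzyl ring. Nothing shown bears on the cause of the step.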